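A few compounds are considered here, and "the series" means these few. Any claim that something is new, unique, unknown or untested is made for them only; others in the source may bear on it.

Measured compounds in a functional assay on A-431 cells (Homo sapiens) for cytotoxicity, read by MTT assay, with a stated time of 48 h; a higher number here means a weaker inhibitor, a lower number a stronger inhibitor:
compound 1 `CCCCCCCCCCCCCCNC(=O)[C@@H](N)[C@@H](C)O`, 14600 nM;
compound 2 `CCCCCCCCCCCCCCCCCCNC(=O)[C@@H](N)[C@@H](C)O`, 21300 nM;
compound 3 `CCCCCCCCCCCCNC(=O)[C@@H](NS(=O)(=O)c1cccs1)[C@@H](C)O`, 22000 nM.

Compound 2 shows the second highest of the three numbers; its nearest neighbour is compound 3 and compound 1 lies furthest from it, yet both gaps fall within the scatter. Going by the values given here, the step of a 1.5-fold higher number from compound 1 to compound 2 (0.16 log units; within the scatter) is the only single-point change among the measured compounds, and it does not touch the amine nitrogen. Compound 4 `CCCCCCCCCCCCCCCCCCNC(=O)[C@@H](NC(=O)c1nccc2ccccc12)[C@@H](C)O` carries (isoquinolin-1-yl)carbonyl in place of hydrogen on an amine nitrogen. Among the compounds with values here, no measured step bears directly on this change; compound 3, which bears a different group on that nitrogen together with a shorter chain, shows a number close to those of compounds 1 and 2. Compound 4 is therefore expected to give a number in this assay close to that of compound 2, a step of a 1.3-fold lower number from compound 2 to compound 4 (0.12 log units; within the scatter), estimated at 16000 nM with a range from 5000 nM to 50000 nM.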

Compound 4, half-maximal inhibitory concentration: 44100 nM
For compound 4 the middle estimate is 2.8-fold (0.44 log units) below the measured one; the range from low to high includes it.
By their numbers in this assay, from the lowest: compounds 1, 2, 3 and 4 (each within the scatter of the next, the first and the last beyond it).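

In this assay, (isoquinolin-1-yl)carbonyl in place of hydrogen on the amine nitrogen gives a 2.1-fold higher number from compound 2 to compound 4 (0.32 log units; beyond the scatter). This is the first single-point change read at this nitrogen and the only listed step beyond the scatter, showing that this large group weakens the compound only modestly. No measurement shown accounts for the shift. On these data alone, whether an acetyl or benzoyl group on this nitrogen would give a similar number remains open. So does whether a tetradecyl chain would alter the effect of (isoquinolin-1-yl)carbonyl.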